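The source may report more compounds than this note shows. Statements on the series, on what has been measured and on what is new or still open speak of the compounds shown alone.

Values in an ADME assay on microsomes from liver (Homo sapiens) for metabolic stability, read by LC-MS, using NADPH, tested at 1 uM (a higher number here means that the compound lasts longer, a lower number that the compound disappears faster), so far:
compound 1, `Cc1cnc(NC(=O)CCCOc2cccc(C#N)c2)s1`: 0.167 h
compound 2, `N#Cc1cnc(NC(=O)CCCOc2cccc(C(F)(F)F)c2)s1`: 1.33 h

Compound 2 holds the highest number of the two; its gap to compound 1 lies beyond the scatter, yet the two compounds differ at more than one place, so no single change can be credited with it. Compound 3, `N#Cc1cnc(NC(=O)CCCOc2ccccc2)s1`, follows from compound 2 by one change: hydrogen in place of trifluoromethyl on an aromatic carbon. Going by the values given here, no measured pair shows this change, so its effect in this assay is not known from the data at hand. With nothing to anchor the step, a drop of moderate size is expected for compound 3, since compound 2 stands at 1.33 h and the change leaves the shared core with hydrogen where trifluoromethyl stood. The expected step is a 2.2-fold lower number from compound 2 to compound 3 (0.35 log units; beyond the scatter), most likely downward, though it may fall within the scatter. Compound 3 is estimated at 0.6 h, in the range 0.25 h to 1.5 h.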

Compound 3, half-life in the Homo sapiens assay: 0.15 h
For compound 3 the middle estimate is 4.0-fold (0.60 log units) above the measured one; measured number outside the range, below it.
By their numbers in the Homo sapiens assay, from the lowest: compounds 3 and 1 (each within the scatter of the next); then compound 2.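

Hydrogen in place of trifluoromethyl on an aromatic carbon, meta to a large group, gives in the Homo sapiens assay an 8.9-fold lower number from compound 2 to compound 3 (0.95 log units; beyond the scatter), the first step of the series that can be tied to a single place, and it shows that the number in this assay depends on what sits at this position. In a physicochemical assay for solubility, read by nephelometry, at pH 2 (on this read-out lower numbers stand for lower solubility and higher numbers for higher solubility), compound 2 gives < 1600 nM, which is a limit of the assay and not a number: the limit of < 1600 nM in the physicochemical assay, at which 1 of the 2 values shown sits. In the physicochemical assay compound 3 gives 1100 nM, and the step for this change in that read-out cannot be read.

Going by these compounds, it remains open whether a chlorine atom or a methoxy group at this place would keep the half-life of compound 2 in the Homo sapiens assay. On these data alone, it also remains open whether the step carries over to the core of compound 1, which differs from compound 2 in more than one place.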